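Working notes on aryl variation in a growth-inhibition series

The source may hold more compounds than are shown below. What is called first, only, known or untested is meant among the compounds shown, and "the series" means these compounds.

Measured compounds:
compound 1 `CN1CCN(CCCOc2cccc3nc(Nc4cccc(Cl)c4)ccc23)CC1` 1900 nM
compound 2 `CN1CCN(CCCOc2cccc3nc(Nc4cc(Cl)cc(Cl)c4)ccc23)CC1` 1730 nM

In a functional assay on cells (Panel prostate (Carcinoma cell lines), Homo sapiens) for inhibition, read by sulforhodamine B assay, with a stated time of 48 h (a lower number here means a stronger inhibitor of growth, a higher number a weaker inhibitor of growth), compound 1 gives 1900 nM and compound 2 gives 1730 nM. For the measured compounds named here, the only step between them is a 1.1-fold lower number from compound 1 to compound 2 (0.04 log units; within the scatter); the two numbers sit within the scatter of each other, so compound 2 cannot be set apart from compound 1 on this assay, and the series so far shows a single flat point.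

Compound 3 `CN1CCN(CCCOc2cccc3nc(Nc4ccc(Cl)c(C(F)(F)F)c4)ccc23)CC1` differs from compound 2 by 4-chloro-3-(trifluoromethyl)phenyl in place of 3,5-dichlorophenyl on a nitrogen on an aromatic ring. Going by the values given here, the one measured step that bears on this change is a 1.1-fold lower number from compound 1 to compound 2 (0.04 log units; within the scatter), which shows that adding a chloro to the phenyl did not move this assay beyond the scatter. Compound 3 keeps one chloro and replaces the other with a trifluoromethyl, a change of the same kind on the same ring, and nothing measured speaks for a shift beyond the scatter. The expected step is a 1.0-fold lower number from compound 2 to compound 3 (0.01 log units; within the scatter), with no direction favoured.

For compound 3 the estimate in this assay is 1700 nM, expected to lie between 800 nM and 3600 nM.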

Compound 3, concentration for 50% growth inhibition: 1690 nM
Compound 3: middle estimate off by 1.0-fold (0.00 log units), on the high side; measured number inside the range.
By their numbers in this assay, from the lowest: compounds 3, 2 and 1 (each within the scatter of the next).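

All three compounds now sit within the scatter of each other in this assay, and the new steps say the same: a 1.0-fold lower number from compound 2 to compound 3 (0.01 log units; within the scatter), and a 1.1-fold lower number from compound 1 to compound 3 (0.05 log units; within the scatter). The earlier pair showed only that a second chloro left the number flat, whereas compound 3 shows that this flatness also holds when a trifluoromethyl enters on the phenyl and the group on the nitrogen goes from 8 to 11 heavy atoms. At this place, among these three compounds, the read-out therefore does not separate 3-chlorophenyl, 3,5-dichlorophenyl and 4-chloro-3-(trifluoromethyl)phenyl, and no measurement at hand offers an explanation for this.

What remains open is whether this position responds at all, since every group shown is a chloro-bearing phenyl, and a phenyl carrying an amine or a carboxylic acid, or a saturated ring such as cyclohexyl in its place, could tell a genuinely indifferent position from a narrow sample. The shared core and its side chain are also constant here, so the compounds shown say nothing about a shorter or longer chain in that part of the structure.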